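A few compounds are considered here, and "the series" means these few. Any claim that something is new, unique, unknown or untested is made for them only; others in the source may bear on it.

Measured so far:
- compound 1, `CC#C[C@@H](CC(=O)O)c1ccc(OC[C@H]2COc3ccc(Br)cc3O2)cc1`: 69%
- compound 2, `CC#C[C@@H](CC(=O)O)c1ccc(OC[C@H]2COc3ccc(C#N)cc3O2)cc1`: 60%

Both were tested in a functional assay on HEK293 cells for agonist activity at Free fatty acid receptor 1 (Homo sapiens), read by fluorescence and calcium flux, with a stated time of 10 min; on this read-out higher numbers stand for larger maximal responses and lower numbers for smaller maximal responses. Compound 2 gives the lowest of the two numbers, and its nearest neighbour is compound 1, whose number lies within the scatter of it: the step of a number 9 percentage points lower from compound 1 to compound 2 (within the scatter) is too small to count as a real change.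

Compound 3, `CC#C[C@@H](CC(=O)O)c1ccc(OC[C@H]2COc3ccc(C(=O)N(C)C)cc3O2)cc1`, has not been measured yet. It differs from compound 2 in one place: dimethylcarbamoyl in place of cyano on an aromatic carbon.

For the measured compounds named here, only one measured step bears on this change, and it is the bromo-to-cyano step, which stayed within the scatter. Going by the values given here, no measured step shows what a dimethylcarbamoyl does at this place, so the expectation rests on the single neighbouring number alone.

Compound 3 is therefore expected to give about 60%, within a range of 40% to 80%; the estimated step of no change at the digits printed from compound 2 to compound 3 (within the scatter) is expected to stay close to the scatter, with no direction claimed.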

Compound 3, largest response reached (Emax), in percent of the reference or control that the assay uses: 32%
Compound 3: the middle estimate sits 28 percentage points above what was measured, outside the stated range (below it).
By their numbers in this assay, from the lowest: compound 3; then compounds 2 and 1 (each within the scatter of the next).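

Up to this point, the swap of bromo for cyano on this aromatic carbon had stayed within the scatter, so the position could have seemed indifferent to the group it carries. In this assay the dimethylcarbamoyl group changes that picture: there is a number 28 percentage points lower from compound 2 to compound 3 (beyond the scatter) and likewise a number 37 percentage points lower from compound 1 to compound 3 (beyond the scatter) in the same read-out, so the group on this carbon can clearly alter the largest response reached. No measurement shown here gives a reason for this drop.

From the compounds shown here alone, it remains open whether the drop belongs to the amide as a whole or to its two methyl groups, a question that an unsubstituted carboxamide or a methyl ester on this carbon could help to separate. Going by these compounds, how an amine, a carboxylic acid or a longer chain would behave at this place also remains open.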